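The source may hold more compounds than are shown below. What is called first, only, known or untested is meant among the compounds shown, and "the series" means these compounds.

Working notes on the oxamic acid series. Within the data shown here, compound 1 `CNc1cccc(NC(=O)C(=O)O)c1C#N` and compound 2 `CCN(CC)c1cccc(NC(=O)C(=O)O)c1C#N` are the two measured members. In a functional assay on the whole organism for inhibition, with Rattus norvegicus as the target, at a dose of 1 mg/kg by the oral route (a higher number here means more inhibition at the dose given (going by the name of the read-out), a lower number less inhibition), compound 1 gives 96%; in this assay compound 2 gives 99.2%. The one measured step, a number 3.2 percentage points higher from compound 1 to compound 2 (within the scatter), is within the scatter, so on the numbers shown compound 2 sits alongside compound 1 with no order between them.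

Compound 3 `COC(=O)c1cccc(NC(=O)C(=O)O)c1C#N` is not yet measured. It differs from compound 2 as follows: methoxycarbonyl in place of diethylamino on an aromatic carbon. Among the measured compounds shown here, the measured step concerns only an exchange of one amino group for another; no measured pair involves a methoxycarbonyl group, so that step does not bear on this change, and the direction in this assay is open. Compound 3 is expected to give 75%, within a range from 30% to 99%. For compound 3 that estimate means an expected step of a number 24.2 percentage points lower from compound 2 to compound 3 (beyond the scatter).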

Compound 3, a percentage reported as inhibition, in the whole organism at one dose (the size of the read-out at that dose, not a potency): 24.5%
Compound 3: middle estimate off by 50.5 percentage points, on the high side; measured number below the stated range.
By their numbers in this assay, from the lowest: compound 3; then compounds 1 and 2 (each within the scatter of the next).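

In this assay, the group on this aromatic carbon, ortho to a cyano group, clearly matters: a number 74.7 percentage points lower from compound 2 to compound 3 (beyond the scatter) when methoxycarbonyl replaces diethylamino, and a number 71.5 percentage points lower from compound 1 to compound 3 (beyond the scatter) when it replaces methylamino. The earlier exchange of one amino group for another gave only a step within the scatter, so the two amino compounds showed no such sensitivity, and only the change to methoxycarbonyl separates compound 3 from them. No measured information accounts for these steps.

As far as these compounds go, whether the loss is tied to methoxycarbonyl itself or would extend to other non-amino groups stays open; a carboxylic acid or a primary amide here would help to tell these apart. Also open, from the compounds shown here alone, is whether compound 1 and compound 2 would separate at a lower oral dose.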